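The source may hold more compounds than are shown below. What is called first, only, known or untested is meant among the compounds shown, and "the series" means these compounds.

Compound 1 (`COC(=O)N(C)CC#CCn1ccnc1`) gives 2 mg/kg
Compound 2 (`CCOC(=O)N(C)CC#CCN1CCCC1`) gives 66 mg/kg

In a functional assay on the whole organism for agonist activity, with Mus musculus as the target (a higher number here means that more compound is needed for the effect, a lower number that less compound is needed), compound 2 stands at 66 mg/kg and has the higher number of the two, beyond the scatter from compound 1. Compound 3 (`CCOC(=O)N(C)CC#CCn1ccnc1`) is not yet measured. It has 1H-imidazol-1-yl in place of pyrrolidin-1-yl on a saturated chain carbon bound to a triple-bonded carbon. Within the data shown here, no measured step isolates this change. Compound 1 gives 2 mg/kg and also carries 1H-imidazol-1-yl, so a lower number, beyond the scatter, is expected. The expected step is large (an 11-fold lower number from compound 2 to compound 3 (1.04 log units; beyond the scatter)). For compound 3 the estimate is 6 mg/kg with an expected range of 1.5 mg/kg to 30 mg/kg as its bounds.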

Compound 3, dose for half-maximal effect: > 100 mg/kg
Compound 3: a limit, no number; the forecaster's own chance of this, stated with the estimate: 10%; middle value at least 16-fold (1.22 log units) away from the limit.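

Compound 3 gives > 100 mg/kg in this assay, a limit of the assay and not a number. With 1H-imidazol-1-yl held fixed, methyl in place of hydrogen on a saturated chain carbon bound to an oxygen next to a carbonyl group gives an at least 50-fold higher number from compound 1 to compound 3 (1.69 log units; beyond the scatter), so the low number of compound 1 does not follow from 1H-imidazol-1-yl alone. With that methyl present, 1H-imidazol-1-yl in place of pyrrolidin-1-yl gives an at least 1.5-fold higher number from compound 2 to compound 3 (0.18 log units; that floor lies within the scatter), and no gain from the swap appears.

Open, as far as these compounds go, is what number pyrrolidin-1-yl gives with hydrogen in place of that methyl. A propyl chain at the same oxygen also remains to be read.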